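The source may report more compounds than this note shows. Statements on the series, on what has been measured and on what is new or still open speak of the compounds shown alone.

In an ADME assay on HEK293 cells (Homo sapiens) for cytotoxicity, read by MTT assay, with a stated time of 48 h (a higher number here means a weaker inhibitor, a lower number a stronger inhibitor), compound 1 (`COc1ccc(-c2nc(SCC(=O)c3sc(-c4ccccc4)nc3C)[nH]c(=O)c2C#N)cc1`) gives 76200 nM and compound 2 (`COc1ccc(-c2nc(C)c(C(=O)CSc3nc(-c4cccc(OC)c4)c(C#N)c(=O)[nH]3)s2)cc1`) gives 95400 nM as its reading, so the two values lie within the usual scatter of each other. Compound 3 (`COc1cccc(-c2nc(SCC(=O)c3sc(-c4ccccc4)nc3C)[nH]c(=O)c2C#N)c1`) is still unmeasured. Compared with compound 2, it has hydrogen in place of methoxy on an aromatic carbon, turning a 4-methoxyphenyl into a phenyl. For the measured compounds named here, no measured pair shows this change on its own, so no shift beyond the scatter is expected. The expected move is a 1.2-fold lower number from compound 2 to compound 3 (0.08 log units; within the scatter) and would be a small one. For compound 3 the estimate is 80000 nM with a range from 40000 nM to 160000 nM in this reading.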

Compound 3, half-maximal inhibitory concentration: 90200 nM
Beside the measured number, compound 3's estimate is 1.1-fold (0.05 log units) below it; low and high end bracket the measured number.
By their numbers in this assay, from the lowest: compounds 1, 3 and 2 (each within the scatter of the next).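

In this assay, for the compounds shown here, hydrogen in place of methoxy on an aromatic carbon, para to a large group, gives a 1.1-fold lower number from compound 2 to compound 3 (0.02 log units; within the scatter) as the first reading of this swap. Putting 3-methoxyphenyl in place of 4-methoxyphenyl gives a 1.2-fold higher number from compound 1 to compound 3 (0.07 log units; within the scatter), so neither the presence of this methoxy nor the difference between these two placements moves the reading beyond the scatter. Nothing available explains these readings.
As far as these compounds go, whether an amine or a carboxylic acid on that aromatic carbon would move the reading beyond the scatter remains open. So does the effect of a longer chain there.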